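The source may hold more compounds than are shown below. What is called first, only, known or untested is meant among the compounds shown, and "the series" means these compounds.

Working notes on the endoperoxide series. Three compounds have results in a functional assay on NCI-H322M cells (Homo sapiens) for inhibition; a higher number here means a weaker inhibitor of growth, a lower number a stronger inhibitor of growth. Compound 1 `COC(=O)[C@H](C)[C@H]1CC[C@@](C)(CCC2=C(C)CCCC2(C)C)OO1` carries a methyl ester and a saturated ring side chain; in this assay compound 1 reaches only the limit > 25000 nM, a bound of the assay rather than a number. Compound 2 `C=C1CCCC(C)(C)C1(O)CC/C(C)=C/CC[C@]1(C)CC[C@@H]([C@@H](C)C(=O)OC)OO1`, an ester with a hydroxylated core, likewise stops at the limit > 17500 nM, again not a number. Going by the values given here, compound 3 `C=C1CCCC(C)(C)C1CC[C@@]1(C)CC[C@H]([C@@H](C)C(=O)O)OO1`, the free acid, is the one compound with a measured value: in this assay compound 3 gives 12500 nM. Among the three values shown, compound 3 thus holds the only number, the other two being limits, as the lines the limit of > 17500 nM in this assay, at which 1 of the 3 values shown sits, and the limit of > 25000 nM in this assay, at which 1 of the 3 values shown sits, record.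

Compound 4 `C=C1CCCC(C)(C)C1CC[C@]1(C)CC[C@@H]([C@@H](C)C(=O)O)OO1` is the diastereomer of compound 3: the two compounds have the same atoms and bonds; at least one stereo element is drawn with a configuration in one of them and without one in the other: 2 of 4 stereo elements differ; a stereocentre at a saturated ring carbon is drawn S in compound 3 and R in compound 4; a stereocentre at a saturated ring carbon is drawn R in compound 3 and S in compound 4. Among the compounds with values here, no measured step between compounds exists, so no direction can be drawn from the data. The expectation is a step from compound 3 to compound 4 of a 1.2-fold higher number from compound 3 to compound 4 (0.08 log units; within the scatter), within the usual scatter. For compound 4 the estimated value in this assay is 15000 nM, expected between 6000 nM and 40000 nM.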

Compound 4, concentration for 50% growth inhibition: > 10000 nM
Compound 4: a limit, no number (the forecaster's own chance of this, stated with the estimate: 40%); the middle value is on the limit's open side.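

Compound 4 gives only a limit in this assay, > 10000 nM, which is not a number. Going by these compounds alone, no step between compound 3 and compound 4 can be read from it. The compounds shown leave open whether the configuration at the two saturated ring carbons affects growth inhibition.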